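From phenoxymethyl to 4-methoxyphenyl on a carbonyl carbon

A few compounds are considered here, and "the series" means these few. Any claim that something is new, unique, unknown or untested is made for them only; others in the source may bear on it.

Of the compounds shown here, two built on a shared core have been tested so far. Among the compounds with values here, in a functional assay on NP14 cells (Homo sapiens) for cytotoxicity, read by MTT assay, with a stated time of 48 h (on this read-out lower numbers stand for stronger inhibition and higher numbers for weaker inhibition), compound 1 `C=C1CC[C@@H]2[C@](C)(COC(=O)COc3ccccc3)[C@H](O)CC[C@@]2(C)[C@@H]1CCc1ccoc1` gives 18600 nM, the only true number available. Compound 2 `C=C1CC[C@@H]2[C@](C)(COC(=O)c3ccc([N+](=O)[O-])cc3)[C@H](OC(=O)c3ccc([N+](=O)[O-])cc3)CC[C@@]2(C)[C@@H]1CCc1ccoc1` gives > 100000 nM in this assay, and this is a limit rather than a number. Within the data shown here, compound 1 therefore stands alone as the single quantified point, and no step between measured compounds is available as a guide.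

Compound 3 `C=C1CC[C@@H]2[C@](C)(COC(=O)c3ccc(OC)cc3)[C@H](O)CC[C@@]2(C)[C@@H]1CCc1ccoc1` has yet to be measured in this assay. It differs from compound 1 in one place: 4-methoxyphenyl in place of phenoxymethyl on a carbonyl carbon. The two groups are exchanged on a carbonyl carbon, and the two compounds have the same atoms, joined differently. Among the measured compounds shown here, the expectation rests on compound 1 at 18600 nM, with no measured precedent for this exchange. No step beyond the usual scatter is expected, though any shift may lean toward weaker inhibition. The expected step is a 1.3-fold higher number from compound 1 to compound 3 (0.13 log units; within the scatter). For compound 3 the estimated value is 25000 nM, with an expected range from 9000 nM to 70000 nM.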

Compound 3, half-maximal inhibitory concentration: 40400 nM
The estimate for compound 3 lay 1.6-fold (0.21 log units) below the measured number; low and high end bracket the measured number.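

The exchange gives the series its first readable step: in this assay, 4-methoxyphenyl in place of phenoxymethyl on a carbonyl carbon gives a 2.2-fold higher number from compound 1 to compound 3 (0.34 log units; beyond the scatter). The two groups match in every count taken, with the same heavy atoms, the same aromatic ring and the same hydrogen-bond tally, so this position registers a change in how those atoms are joined even when their number and kind stay fixed. Of this pair, compound 1 holds the lower number, and the step runs toward weaker inhibition, though both compounds remain measurable in this read-out.

Within the data shown here, compound 2 differs from compound 1 in more than one place, and its value is a limit rather than a number, so it adds no step to set beside this one: the limit of > 100000 nM in this assay, at which 1 of the 3 values shown sits. What stays open is which part of the change carries the step, the loss of the link between carbonyl and ring or the methoxy group on the ring, and how a plain phenyl, a 4-aminophenyl or a longer alkyl chain on the same carbonyl carbon would read against compound 1.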